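From a capped carbonyl to a free carboxy group

The source may hold more compounds than are shown below. What is called first, only, known or untested is meant among the compounds shown, and "the series" means these compounds.

- compound 1 `C=C(C)CCOC(=O)C[C@@H]1C(C(=O)OC)=CO[C@@H](O[C@@H]2O[C@H](COC(C)=O)[C@@H](OC(C)=O)[C@H](OC(C)=O)[C@H]2OC(C)=O)/C1=C/C`: > 15000 nM
- compound 2 `C/C=C1/[C@H](O[C@@H]2O[C@H](CO)[C@@H](O)[C@H](O)[C@H]2O)OC=C(C(=O)OC)[C@H]1CC(=O)OCCc1ccc2c(c1)OCCO2`: > 20000 nM
- compound 3 `C/C=C1/[C@H](O[C@@H]2O[C@H](CO)[C@@H](O)[C@H](O)[C@H]2O)OC=C(C(=O)OC)[C@H]1CC(=O)OCCCCCCCCCCCCCCC`: 1600 nM

All three compounds were measured in a functional assay on SK-BR-3 cells (Homo sapiens) for antiproliferative activity, read by MTT assay, with a stated time of 72 h; on this read-out lower numbers stand for stronger inhibition and higher numbers for weaker inhibition. Compound 1 stands at > 15000 nM, and this is a limit of the assay, not a number. Compound 2 also gives only a limit, > 20000 nM. Compound 3 is the only one of the three with a true number, 1600 nM.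

The next compound to be measured is compound 4 `C/C=C1/[C@H](O[C@@H]2O[C@H](COC(C)=O)[C@@H](OC(C)=O)[C@H](OC(C)=O)[C@H]2OC(C)=O)OC=C(C(=O)OC)[C@H]1CC(=O)O`. It keeps the core of compound 1 and changes in one place: hydrogen in place of 3-methylbut-3-en-1-yl on an oxygen next to a carbonyl group. Put simply, hydrogen takes the place of 3-methylbut-3-en-1-yl on an oxygen next to a carbonyl group, so ((3-methylbut-3-en-1-yl)oxy)carbonyl becomes carboxy.

Within the data shown here, no measured pair of compounds shows what this change does, so any forecast is uncertain. It rests mainly on compound 1, whose limit of > 15000 nM gives no sign of activity to build on. In this assay no gain beyond the scatter is expected, and the estimated step is a step that the limit leaves unreadable from compound 1 to compound 4. The assay may well report only a limit again. For compound 4 the expected value is 20000 nM, with an estimated range from 10000 nM to 40000 nM.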

Compound 4, half-maximal inhibitory concentration: > 15000 nM
Compound 4: only a limit was reported; the forecaster's own chance of this, stated with the estimate: 75%; the middle value is on the limit's open side.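

Compound 1 and compound 4 both end in a limit of the assay rather than a number, so no step can be read between them: the limit of > 15000 nM in this assay, at which 2 of the 4 values shown sit.

The compounds shown leave open whether replacing ((3-methylbut-3-en-1-yl)oxy)carbonyl with carboxy changes the antiproliferative activity at all, and if it does, in which direction and by how much.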